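Cytotoxicity of an Amide Series: Aryl to Alkyl Swap

A few compounds are considered here, and "the series" means these few. Any claim that something is new, unique, unknown or untested is made for them only; others in the source may bear on it.

Three compounds have been examined in an ADME assay on HepG2 cells (Homo sapiens) for cytotoxicity, read by trypan blue exclusion, with a stated time of 48 h, in the presence of a further agent that is not named here; on this read-out higher numbers stand for lower toxicity in this test and lower numbers for higher toxicity in this test. Compound 1 `c1ccc(Cn2cnc3c(-c4ccco4)nccc32)cc1` reaches only the limit of the test: in this assay compound 1 gives > 25000 nM, a limit and not a number. Compound 2 `COc1ccccc1NC(=O)COc1cc(C)nc2ccc(C(F)(F)F)cc12` likewise ends at a limit: in this assay compound 2 gives > 128000 nM. Going by the values given here, compound 3 `COc1cccc(NC(=O)COc2cc(C)nc3ccc(OC)cc23)c1` is the only one with a measured number: in this assay compound 3 gives 24700 nM. Two of the three results are limits, as shown by the limit of > 128000 nM in this assay, at which 1 of the 3 values shown sits, and (the limit of > 25000 nM in this assay, at which 1 of the 3 values shown sits), so no step between measured compounds can be given, and compound 3 cannot be ordered against the other two.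

Compound 4 `COCCNC(=O)COc1cc(C)nc2ccc(OC)cc12` is not yet measured. It differs from compound 3 by 2-methoxyethyl in place of 3-methoxyphenyl on an amide-type nitrogen. Among the compounds with values here, with no measured step to lean on, the expectation is a modest move toward less toxicity, of a size estimated as a 2.0-fold higher number from compound 3 to compound 4 (0.31 log units; beyond the scatter), though a change no larger than the scatter would not surprise. Compound 4 is therefore expected to give about 50000 nM in this assay, within a range from 15000 nM to 160000 nM, with a real chance that the test reports only a limit.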

Compound 4, half-maximal cytotoxic concentration: > 164000 nM
Compound 4 was reported as a limit (the forecaster's own chance of this, stated with the estimate: 50%); middle value at least 3.2-fold (0.51 log units) away from the limit.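

In this assay, going by these compounds alone, 2-methoxyethyl in place of 3-methoxyphenyl on an amide-type nitrogen gives an at least 6.6-fold higher number from compound 3 to compound 4 (0.82 log units; beyond the scatter), the first step that can be read, and it shows that a change at this position can move the result beyond the scatter. The group that leaves carries a six-membered aromatic ring and the group that enters has no ring, while their counts of hydrogen-bond donors and acceptors match, so the step comes with loss of the ring and not with a change in those counts. Compound 4 ends at a limit, and the step gives only a lower bound on the change: the limit of > 164000 nM in this assay, at which 1 of the 4 values shown sits.

This single pair cannot separate the loss of the aromatic ring from the drop in group size. From the compounds shown here alone, whether a cyclohexyl group, which keeps a ring but is not aromatic, or a 2-aminoethyl chain would fall nearer compound 3 or compound 4 stays open.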